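Selenol in place of a selenium-pentyl group

The compounds below may be only part of what the source reports. "The series", "measured", "known", "first", "only" and "open" are said of these compounds alone.

Of the compounds shown here, three that share one core have been tested in a functional assay on CCRF-CEM cells (Homo sapiens) for cytotoxicity, read by MTT assay, with a stated time of 72 h; a lower number here means a stronger inhibitor of growth, a higher number a weaker inhibitor of growth. Compound 1, `C[Se]c1nc(N)c2ccccc2n1`, carries a methyl on its selenium and an unsubstituted amino group. In this assay compound 1 reaches only a limit, > 100000 nM. Compound 2, `COc1ccc(CNc2nc([SeH])nc3ccccc23)cc1`, has a bare selenol and a methoxy-substituted benzyl group on the nitrogen. For compound 2 this assay likewise gives only a limit, > 100000 nM. Within the data shown here, compound 3, `CCCCC[Se]c1nc(NCc2ccc(SC)cc2)c2ccccc2n1`, pairs a pentyl on the selenium with a methylthio-substituted benzyl group; in this assay compound 3 gives 83900 nM, the only actual number among the three.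

Compound 4, `CSc1ccc(CNc2nc([SeH])nc3ccccc23)cc1`, has not yet been measured. It differs from compound 3 in one place: hydrogen in place of pentyl on a selenium. Among the measured compounds shown here, no measured pair of compounds differs in exactly this way, so no step is known for it. Compound 4 is expected to sit at or near the limit, because of the limit of > 100000 nM in this assay, at which 2 of the 3 values shown sit. The expected step of a 1.3-fold higher number from compound 3 to compound 4 (0.12 log units; within the scatter) is small, toward weaker growth inhibition, and not beyond the usual scatter. Compound 4 is therefore estimated at 110000 nM, within a range from 50000 nM to 300000 nM.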

Compound 4, concentration for total growth inhibition: > 100000 nM
Compound 4 gave a limit, no number; the forecaster's own chance of this, stated with the estimate: 60%; the middle value lies beyond the limit too.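

Hydrogen in place of pentyl on a selenium can now be judged from a measured pair, and in this assay this change gives an at least 1.1-fold higher number from compound 3 to compound 4 (0.07 log units; that floor lies within the scatter). That figure is only a floor, set by the limit reached by compound 4, so the real step may be small or large, and the data show only that the bare selenol gave no number here. The change from methoxy to methylsulfanyl on an aromatic carbon, the one place where compound 2 and compound 4 differ, cannot be read, because both compounds sit at the limit: the limit of > 100000 nM in this assay, at which 3 of the 4 values shown sit.

Among these compounds, how far the growth inhibition of compound 3 depends on the length of the chain on the selenium stays open, since pentyl and hydrogen are the only two groups compared there with the rest of the molecule unchanged. A longer chain such as octyl, or a pentyl chain carrying a carboxylic acid, on the same core would show whether this position can give a number well clear of the limit.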